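The source may hold more compounds than are shown below. What is called first, only, known or untested is meant among the compounds shown, and "the series" means these compounds.

Of the compounds shown here, three sharing one core have been measured in an assay on CHO cells for displacement of a labelled ligand from prostaglandin D2 receptor 2 (Homo sapiens), read by scintillation counting; a higher number here means a weaker inhibitor, a lower number a stronger inhibitor. Compound 1 `C[S+]([O-])c1cccc(C#Cc2cc(Cl)ccc2OCC(=O)O)c1` gives 3.2 nM, compound 2 `CS(=O)(=O)Cc1cccc(C#Cc2cc(Cl)ccc2OCC(=O)O)c1` gives 48 nM, and compound 3 `O=C(O)COc1ccc(Cl)cc1C#Cc1ccccc1` gives 108 nM. Compound 3 thus stands at the highest number of the three and is the weakest inhibitor of the set: its steps to the others are a 2.3-fold higher number from compound 2 to compound 3 (0.35 log units; beyond the scatter) and a 34-fold higher number from compound 1 to compound 3 (1.53 log units; beyond the scatter), both beyond the scatter.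

Compound 4 `CN(C)S(=O)(=O)c1cccc(C#Cc2cc(Cl)ccc2OCC(=O)O)c1` has not yet been measured. It differs from compound 3 in one place: dimethylsulfamoyl in place of hydrogen on an aromatic carbon, on an aromatic carbon of a six-membered aromatic ring of carbon only, meta to a large group. Among the compounds with values here, two measured steps bear on this, since each also concerns a sulfur-bearing group at that carbon. The step of a 34-fold higher number from compound 1 to compound 3 (1.53 log units; beyond the scatter) is large, and the step of a 2.3-fold higher number from compound 2 to compound 3 (0.35 log units; beyond the scatter) is modest, so putting such a group in this place has gone with a lower number in both known cases. A step downward beyond the scatter is therefore expected for compound 4, its size lying somewhere between the two precedents. Compound 4 is estimated to give about 18 nM in this assay, within a range from 4 nM to 80 nM, which corresponds to an expected step of a 6.0-fold lower number from compound 3 to compound 4 (0.78 log units; beyond the scatter).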

Compound 4, inhibition constant: 14 nM
The estimate for compound 4 lay 1.3-fold (0.11 log units) above the measured number; the measured number falls inside the stated range.
By their numbers in this assay, from the lowest: compound 1; then compound 4; then compound 2; then compound 3.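

In this assay, dimethylsulfamoyl at this aromatic carbon gives a clear gain over hydrogen (a 7.7-fold lower number from compound 3 to compound 4 (0.89 log units; beyond the scatter)), so all three sulfur-bearing groups tested here go with a lower number than hydrogen. It also outperforms (methylsulfonyl)methyl (a 3.4-fold lower number from compound 2 to compound 4 (0.54 log units; beyond the scatter)), showing that the exact sulfur-bearing group matters and not merely the presence of sulfur at this carbon. Size alone does not order the set: the smaller group of compound 1 still gives the lowest number (a 4.4-fold higher number from compound 1 to compound 4 (0.64 log units; beyond the scatter)), while the larger dimethylsulfamoyl falls short of it, and (methylsulfonyl)methyl, smaller than dimethylsulfamoyl, does worse. Nothing available explains these differences. As far as these compounds go, whether sulfur is needed at all remains open, as no group without it, such as a carboxylic acid or an amine, appears at this carbon, and neither does a longer chain on the nitrogen of the dimethylsulfamoyl group.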